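A few compounds are considered here, and "the series" means these few. Any claim that something is new, unique, unknown or untested is made for them only; others in the source may bear on it.

Measured compounds:
compound 1 `CC(C)[C@@H](O)CNC(C)(C)CC(=O)N[C@@H]1CCc2ccccc2N(Cc2ccc(-c3ccccc3-c3nn[nH]n3)cc2)C1=O` with 200 nM
compound 2 `CC(C)(CC(=O)N[C@@H]1CCc2ccccc2N(Cc2ccc(-c3ccccc3-c3nn[nH]n3)cc2)C1=O)NC[C@H](O)CO` with 10 nM
compound 3 `CC(C)(N)C(=O)N[C@@H]1CCc2ccccc2N(Cc2ccc(-c3ccccc3-c3nn[nH]n3)cc2)C1=O` with 30 nM

In a functional assay (Pituitary gland cell) with Rattus norvegicus as the target (on this read-out lower numbers stand for an effect already at smaller amounts and higher numbers for an effect only at larger amounts of compound), compound 3 gives 30 nM, the second highest of the three numbers; compound 2 sits closest to it (a 3.0-fold higher number from compound 2 to compound 3 (0.48 log units; beyond the scatter)), while compound 1 lies furthest (a 6.7-fold lower number from compound 1 to compound 3 (0.82 log units; beyond the scatter)). Compound 4 `CC(=O)O[C@@H](C)CNC(C)(C)CC(=O)N[C@@H]1CCc2ccccc2N(Cc2ccc(-c3ccccc3-c3nn[nH]n3)cc2)C1=O` has not yet been measured. Its structure differs from compound 3 in one place: 2-((2-acetoxypropyl)amino)-2-methylpropyl in place of 1-amino-1-methylethyl on a carbonyl carbon. Within the data shown here, two measured steps bear on this kind of change at the carbonyl carbon. Replacing a longer chain that carries a hydroxyl by the short 1-amino-1-methylethyl group gave a 6.7-fold lower number from compound 1 to compound 3 (0.82 log units; beyond the scatter), whereas the same replacement from a chain carrying two hydroxyls gave a 3.0-fold higher number from compound 2 to compound 3 (0.48 log units; beyond the scatter); the direction therefore depended on the chain, and compound 4 carries an acetoxypropyl chain, with no measured parallel. The expected step for this assay is a 1.7-fold higher number from compound 3 to compound 4 (0.22 log units; within the scatter), a change that may not exceed the scatter. Compound 4 is estimated at 50 nM, within a range from 12 nM to 200 nM.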

Compound 4, concentration for half-maximal effect: 200 nM
Estimate against measurement, compound 4: 4.0-fold (0.60 log units) below; the measured number falls inside the stated range.
By their numbers in this assay, from the lowest: compound 2; then compound 3; then compounds 1 and 4 (each within the scatter of the next).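

In this assay, the 2-((2-acetoxypropyl)amino)-2-methylpropyl chain on the carbonyl carbon gives a 6.7-fold higher number from compound 3 to compound 4 (0.82 log units; beyond the scatter), so a second long chain now has a higher number than the short 1-amino-1-methylethyl group, and compound 2 alone goes against this. On the saturated chain carbon bound to an amine nitrogen, 1-acetoxyethyl in place of 1,2-dihydroxyethyl gives a 20-fold higher number from compound 2 to compound 4 (1.30 log units; beyond the scatter), while 1-acetoxyethyl in place of 1-hydroxy-2-methylpropyl gives no change at the digits printed from compound 1 to compound 4 (within the scatter), which leaves the dihydroxy chain of compound 2 as the only long chain with a low number. Nothing measured here accounts for these steps.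

On these data alone, it remains open whether a plain 2-hydroxypropyl chain, without the acetyl, would stand with compound 2 or with compound 1 and compound 4. As far as these compounds go, how a carboxylic acid at the end of the chain would read is also open.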